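This account rests on a few compounds, and the source may have more. Where it says the series, first, only, none or still open, it means among the compounds named here.

Measured in a functional assay on MCF7 cells (Homo sapiens) for antiproliferative activity, read by MTT assay, with a stated time of 72 h; a lower number here means a stronger inhibitor, a higher number a weaker inhibitor:
- compound 1 (`CC1=CC[C@H]2[C@H](CC[C@]2(C)O)C(C)(C)[C@@H]1CC[C@H]1[C@]2(C)CC[C@H](OC(=O)NCc3ccccc3)C(C)(C)O[C@H]2CC[C@@]1(C)O`): 24500 nM
- compound 2 (`CC1=CC[C@H]2[C@H](CC[C@]2(C)O)C(C)(C)[C@@H]1CC[C@H]1[C@]2(C)CC[C@H](OC(=O)c3ccc([N+](=O)[O-])cc3)C(C)(C)O[C@H]2CC[C@@]1(C)O`): 21600 nM

Among the measured compounds shown here, compound 2 stands level with compound 1, as the only measured step, a 1.1-fold lower number from compound 1 to compound 2 (0.05 log units; within the scatter), lies within the scatter. Compound 3 (`COc1ccc(C(=O)O[C@H]2CC[C@]3(C)[C@H](CC[C@@](C)(O)[C@H]3CC[C@@H]3C(C)=CC[C@H]4[C@H](CC[C@]4(C)O)C3(C)C)OC2(C)C)cc1`) keeps the shared core and carries methoxy in place of nitro on an aromatic carbon, para to a large group: methoxy in place of nitro on an aromatic carbon. For the measured compounds named here, no measured step makes this exchange directly. The closest evidence is that same step, which replaced the whole 4-nitrophenyl group attached to the carbonyl and left the number within the scatter. That is a single comparison, and it says nothing specific about methoxy. In this assay no shift beyond the scatter is therefore expected, and the estimated change is a 1.0-fold higher number from compound 2 to compound 3 (0.01 log units; within the scatter). For compound 3 the expected value is 22000 nM, with an estimated range of 12000 nM to 40000 nM.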

Compound 3, half-maximal inhibitory concentration: 41700 nM
For compound 3 the middle estimate is 1.9-fold (0.28 log units) below the measured one; the measured number lies above the stated range.
By their numbers in this assay, from the lowest: compounds 2, 1 and 3 (each within the scatter of the next).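

In this assay the direct exchange of nitro for methoxy on the aromatic carbon, para to a large group, gives a 1.9-fold higher number from compound 2 to compound 3 (0.29 log units; within the scatter); this position now has a reading of its own, where earlier only the replacement of the whole 4-nitrophenyl group could be consulted. Setting 4-methoxyphenyl in place of benzylamino on the carbonyl carbon gives a 1.7-fold higher number from compound 1 to compound 3 (0.23 log units; within the scatter), so the three groups carried on the carbonyl all lie within the scatter of one another in this assay. Nothing available here bears on why these numbers fall as they do.

On these data alone, whether an amine or a carboxylic acid on that same aromatic carbon would move the number beyond the scatter remains open. So does the effect of a longer chain in place of the benzylamino group on the carbonyl carbon.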